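Thiourea anilide series: replacing the phenol ring on the core

This account rests on a few compounds, and the source may have more. Where it says the series, first, only, none or still open, it means among the compounds named here.

Compound 1 `CC1=C(C(=O)Nc2ccc(F)c(Cl)c2)C(c2cccc(O)c2)NC(=S)N1` is the reference point in this set. Going by the values given here, in a functional assay on PC-3 cells (Homo sapiens) for cytotoxicity, read by sulforhodamine B assay, with a stated time of 48 h (a higher number here means a weaker inhibitor of growth, a lower number a stronger inhibitor of growth), compound 1 gives 25100 nM, the highest of the three numbers measured so far. Compound 3 `CC1=C(C(=O)Nc2ccc(F)c(Cl)c2)C(c2cccc(Oc3ccccc3)c2)NC(=O)N1` gives 22400 nM, which sits within the usual scatter of compound 1. Among the compounds with values here, compound 2 `CC1=C(C(=O)Nc2ccc(Cl)c(Cl)c2)C(c2cccc(Oc3ccccc3)c2)NC(=S)N1` gives 9770 nM, a lower number that lies beyond the scatter relative to compound 1; compound 2 and compound 3 each differ from compound 1 in more than one place, so no single-change step is available between any two measured compounds.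

Compound 4 `CC1=C(C(=O)Nc2ccc(F)c(Cl)c2)C(c2ccccc2Cl)NC(=S)N1` has not yet been measured in this assay. It differs from compound 1 in one place: 2-chlorophenyl in place of 3-hydroxyphenyl on a saturated ring carbon. The hydroxyl donor and acceptor of compound 1 are thereby removed, and nothing in the measured compounds isolates that change on its own. The expectation for compound 4 is a step of modest size downward in the number, a 1.7-fold lower number from compound 1 to compound 4 (0.22 log units; within the scatter), not clearly beyond the scatter. Compound 4 is therefore estimated at 15000 nM, within a range of 5000 nM to 50000 nM, pending the measurement.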

Compound 4, concentration for 50% growth inhibition: 20400 nM
For compound 4 the middle estimate is 1.4-fold (0.13 log units) below the measured one; the range from low to high includes it.
By their numbers in this assay, from the lowest: compound 2; then compounds 4, 3 and 1 (each within the scatter of the next).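

In this assay, going by these compounds alone, putting 2-chlorophenyl in place of 3-hydroxyphenyl on the saturated ring carbon gives a 1.2-fold lower number from compound 1 to compound 4 (0.09 log units; within the scatter), the first single-change step. At this position the hydroxyl of compound 1 is therefore not needed to hold growth inhibition at the level seen for compound 1, and a chlorine-bearing phenyl ring is tolerated there without a change that can be told from the scatter. No supporting data bear on why the two compounds read alike.

This one swap alters both the substituent and its place on the phenyl ring, so the two changes cannot be separated. From the compounds shown here alone, it also remains open whether an unsubstituted phenyl, a methoxy group or an amine on that ring would move the number beyond the scatter.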